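Changing the aryl group of compound 1

The compounds below may be only part of what the source reports. "The series", "measured", "known", "first", "only" and "open" are said of these compounds alone.

For the measured compounds named here, in a functional assay on HCT-116 cells (Homo sapiens) for antiproliferative activity, read by MTT assay, with a stated time of 72 h (on this read-out lower numbers stand for stronger inhibition of growth and higher numbers for weaker inhibition of growth), compound 1 `Cc1ccc(Cl)cc1-n1nnc(C(=O)Nc2ccc(SC#N)cc2)c1C` gives 8200 nM as the only actual number so far. Compound 2 `Cc1ccc(Cl)c(-n2nnc(C(=O)Nc3ccc(SC#N)cc3)c2C)c1` reads > 100000 nM and that value is a limit of the assay. The change 3-methoxyphenyl in place of 5-chloro-2-methylphenyl on an aromatic nitrogen gives compound 3 `COc1cccc(-n2nnc(C(=O)Nc3ccc(SC#N)cc3)c2C)c1` with 3-methoxyphenyl in place of 5-chloro-2-methylphenyl on an aromatic nitrogen. Going by the values given here, one measured step bears on this place: an at least 12-fold higher number from compound 1 to compound 2 (1.08 log units; beyond the scatter) is large and beyond the scatter, with 2-chloro-5-methylphenyl entering. On that single step a higher number is expected in this assay with the estimated size a 2.4-fold higher number from compound 1 to compound 3 (0.39 log units; beyond the scatter) as a rough guide. Compound 3 is estimated at 20000 nM with 4000 nM to 100000 nM as the expected range.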

Compound 3, concentration for 50% growth inhibition: 39800 nM
Estimate against measurement, compound 3: 2.0-fold (0.30 log units) below; low and high end bracket the measured number.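

Compound 3 shows that this aromatic nitrogen tolerates an aryl group without chlorine and still gives a real number in this assay, though the change to 3-methoxyphenyl costs a 4.9-fold higher number from compound 1 to compound 3 (0.69 log units; beyond the scatter). Of the three aryl groups, 5-chloro-2-methylphenyl in compound 1 keeps the lowest number, while the other comparison gives an at least 2.5-fold lower number from compound 2 to compound 3 (0.40 log units; beyond the scatter). That second step is only a bound, as compound 2 stands at a limit: the limit of > 100000 nM in this assay, at which 1 of the 3 values shown sits.

From the compounds shown here alone, it remains open how an unsubstituted phenyl would read here. The same applies to a phenyl carrying an amine or a carboxylic acid.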